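A few compounds are considered here, and "the series" means these few. Any claim that something is new, unique, unknown or untested is made for them only; others in the source may bear on it.

Measured compounds:
- compound 1, `COC(=O)c1cc(-c2cccc(NC(=O)c3ccc(/C=C/C(=O)c4cccs4)cc3)c2)on1`: "not determined" (no result reported) in an ADME assay on Vero cells (Chlorocebus sabaeus) for cytotoxicity, read by MTT assay, with a stated time of 72 h; on this read-out higher numbers stand for lower toxicity in this test and lower numbers for higher toxicity in this test
- compound 2, `COC(=O)c1cc(-c2cccc(NC(=O)c3ccc(/C=C/C(=O)c4ccc(OC)cc4)cc3)c2)on1`: > 10 ug/mL in this assay

Two compounds share a common core and differ only in the aryl group attached to the carbonyl at the end of the chain. For compound 1 no result was reported in this assay. Compound 2 was tested, and its value of > 10 ug/mL is a limit of the assay rather than a measured number, so its toxicity is only bounded on one side. This is the evidence available: the limit of > 10 ug/mL in this assay, at which 1 of the 2 values shown sits.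

Compound 3, `COC(=O)c1cc(-c2cccc(NC(=O)c3ccc(/C=C/C(=O)c4ccccc4Cl)cc3)c2)on1`, is the next compound to be tested. The change from compound 2 is 2-chlorophenyl in place of 4-methoxyphenyl on a carbonyl carbon. Within the data shown here, no step between two measured compounds is known, so there is nothing to calibrate against. Given that compound 2 sits at the limit, the expectation is that compound 3 will show no change beyond the scatter, a step that the limit leaves unreadable from compound 2 to compound 3. Compound 3 is therefore estimated at 12 ug/mL, with a plausible range from 5 ug/mL to 40 ug/mL.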

Compound 3, half-maximal cytotoxic concentration: > 25 ug/mL
Compound 3: only a limit was reported (the forecaster's own chance of this, stated with the estimate: 65%); middle value at least 2.0-fold (0.31 log units) away from the limit.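

Among these compounds, compound 2 and compound 3 each carry only a limit of the assay, not a number, in this assay, so no step between them can be read. The compounds shown leave open the actual half-maximal cytotoxic concentration of each, and whether 2-chlorophenyl in place of 4-methoxyphenyl on the carbonyl carbon changes it at all.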